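This account rests on a few compounds, and the source may have more. Where it says the series, first, only, none or still open, it means among the compounds named here.

Measured so far in a functional assay on A549 cells (Homo sapiens) for cytotoxicity, read by MTT assay, with a stated time of 24 h; on this read-out lower numbers stand for stronger inhibition and higher numbers for weaker inhibition:
- compound 1 `C=CC1=C(C(=O)NCCC)C(c2ccc(F)cc2)OC1`, a limit of > 100000 nM
- compound 2 `C=CC1=C(C(=O)NC(C)(C)C)C(c2ccc(OC)cc2)OC1`, a limit of > 100000 nM
- compound 3 `C=CC1=C(C(=O)Nc2ccccc2OC)C(c2ccc(F)cc2)OC1`, a limit of > 100000 nM

Compound 2 therefore stands only at a limit in this assay, as do the other two measured compounds, and it cannot be placed in order against them. Compound 4 `C=CC1=C(C(=O)Nc2ccccc2)C(c2ccc(OC)cc2)OC1` differs from compound 2 by phenyl in place of tert-butyl on an amide-type nitrogen. Among the measured compounds shown here, the only measured step that resembles this change, a step that the two limits leave unreadable from compound 1 to compound 3, is itself unreadable, since (the limit of > 100000 nM in this assay, at which 3 of the 3 values shown sit). No readable step bears on the change, so no direction can be expected beyond the scatter. Compound 4 is therefore estimated at 100000 nM, within 30000 nM to 300000 nM, an expected step of a number no higher from compound 2 to compound 4 (the limit leaves the size open).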

Compound 4, half-maximal inhibitory concentration: > 100000 nM
Compound 4 was reported as a limit; the forecaster's own chance of this, stated with the estimate: 85%; the middle value lies on the limit itself.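

Compound 2 and compound 4 both stand only at a limit, so no step between them can be read: the limit of > 100000 nM in this assay, at which 4 of the 4 values shown sit.

Going by these compounds, whether phenyl in place of tert-butyl on an amide-type nitrogen changes the result in this assay at all remains open.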